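The compounds below may be only part of what the source reports. "The series", "measured", "known", "first", "only" and "open" are said of these compounds alone.

Series notes: the shared core of compound 1 `C[C@@H](Cn1ccc(-c2ccc(C#N)c(Cl)c2)n1)NC(=O)c1ccccc1` carries an amide on the side chain, and the amides differ only at the carbonyl carbon or on its aryl group. Going by the values given here, in a functional assay on LNCaP cells (Homo sapiens) for antiproliferative activity, read by CCK-8 assay, with a stated time of 6 days (a higher number here means a weaker inhibitor, a lower number a stronger inhibitor), compound 1 gives 1830 nM, the lowest of the three numbers so far. Compound 2 `CC(O)c1cccc(C(=O)N[C@@H](C)Cn2ccc(-c3ccc(C#N)c(Cl)c3)n2)c1` gives 2280 nM and compound 3 `COC(=O)/C=C/C(=O)N[C@@H](C)Cn1ccc(-c2ccc(C#N)c(Cl)c2)n1` gives 2460 nM; the steps of a 1.2-fold higher number from compound 1 to compound 2 (0.10 log units; within the scatter) and a 1.3-fold higher number from compound 1 to compound 3 (0.13 log units; within the scatter) are both within the scatter, as is a 1.1-fold higher number from compound 2 to compound 3 (0.03 log units; within the scatter), so no order among the three can be read.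

Compound 4 `C[C@@H](Cn1ccc(-c2ccc(C#N)c(Cl)c2)n1)NC(=O)C1CC(=O)C1` is the next member: 3-oxocyclobutyl in place of phenyl on a carbonyl carbon. Among the compounds with values here, the steps that bear on it are those that likewise replace the aryl group on the carbonyl carbon: a 1.3-fold higher number from compound 1 to compound 3 (0.13 log units; within the scatter), where a short unsaturated ester chain took the place of the phenyl, and a 1.1-fold higher number from compound 2 to compound 3 (0.03 log units; within the scatter), where the same chain took the place of a substituted phenyl. Both stayed within the scatter. The data so far therefore give no sign that the benzoyl group is needed for the number seen, and no step beyond the scatter is expected in this assay for compound 4. The expected step is a 1.3-fold higher number from compound 1 to compound 4 (0.12 log units; within the scatter). For compound 4 the estimate is 2400 nM, in the range 1200 nM to 5000 nM.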

Compound 4, half-maximal inhibitory concentration: 3040 nM
Compound 4: middle estimate off by 1.3-fold (0.10 log units), on the low side; measured number inside the range.
By their numbers in this assay, from the lowest: compounds 1, 2, 3 and 4 (each within the scatter of the next).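

Replacing phenyl with 3-oxocyclobutyl on the carbonyl carbon gives a 1.7-fold higher number from compound 1 to compound 4 (0.22 log units; within the scatter) in this assay, so this position now tolerates a four-membered non-aromatic ring carrying one hydrogen-bond acceptor, as well as the open unsaturated ester chain of compound 3, without a step beyond the scatter. The other two comparisons agree, with a 1.2-fold higher number from compound 3 to compound 4 (0.09 log units; within the scatter) and a 1.3-fold higher number from compound 2 to compound 4 (0.12 log units; within the scatter), so the 3-oxocyclobutyl amide cannot be told apart from either the 2-(methoxycarbonyl)ethenyl amide or the 3-(1-hydroxyethyl)phenyl amide, and the aromatic ring on the carbonyl carbon shows no measurable role among these four compounds. No supporting measurement bears on what lies behind these numbers.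

The compounds shown leave open whether any group on this carbonyl carbon can move the number beyond the scatter in either direction, since all the steps among the four compounds lie within it. A primary amine, a carboxylic acid or a longer alkyl chain in place of the 3-oxocyclobutyl would test this, and would show how far the tolerance seen here extends.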